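A few compounds are considered here, and "the series" means these few. Any claim that something is new, unique, unknown or untested is made for them only; others in the source may bear on it.

Among the measured compounds shown here, compound 1 `CC1=C(C(=O)Nc2ccc(F)c(Cl)c2)C(c2cccc(Cl)c2)NC(=S)N1` is the weaker of the two compounds measured so far in a functional assay on CAKI-1 cells (Homo sapiens) for cytotoxicity, read by sulforhodamine B assay, with a stated time of 48 h (on this read-out higher numbers stand for weaker inhibition of growth and lower numbers for stronger inhibition of growth), where compound 1 gives 39800 nM. Its nearest neighbour is compound 2 `CC1=C(C(=O)Nc2ccc(F)c(Cl)c2)C(c2ccccc2Cl)NC(=S)N1`, which in this assay gives 31600 nM; the step of a 1.3-fold lower number from compound 1 to compound 2 (0.10 log units; within the scatter) moves only the chloro on the saturated ring carbon and stays inside the scatter, so the two compounds stand together rather than in order. Compound 3 `CC1=C(C(=O)Nc2ccc(F)c(Cl)c2)C(c2cccc(Oc3ccccc3)c2)NC(=S)N1` differs from compound 1 in a different way: phenoxy in place of chloro on an aromatic carbon. No measured pair exchanges one group for another on that aromatic ring; the one step shown, from compound 1 to compound 2, concerns a position change alone and is flat. On that basis compound 3 is expected to show a step of about a 1.4-fold lower number from compound 1 to compound 3 (0.15 log units; within the scatter) in this assay, most likely within the scatter, with no firm direction. Compound 3 is therefore estimated at 28000 nM, with a range from 8000 nM to 90000 nM.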

Compound 3, concentration for 50% growth inhibition: 12600 nM
Compound 3: the middle estimate sits 2.2-fold (0.35 log units) above what was measured; low and high end bracket the measured number.
By their numbers in this assay, from the lowest: compound 3; then compounds 2 and 1 (each within the scatter of the next).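

In this assay the aromatic ring carbon that holds the chloro turns out to respond to a change of group: phenoxy in place of chloro gives a 3.2-fold lower number from compound 1 to compound 3 (0.50 log units; beyond the scatter) and so moves the number beyond the scatter, which the earlier shift of the chloro did not do. The larger group, with its added six-membered aromatic ring of carbon only, goes with stronger inhibition of growth here, although the step is modest and rests on this one pair. Nothing on hand says what in the phenoxy accounts for the step.

Still open, from the compounds shown here alone, is whether the oxygen link or the second ring carries the step, which a benzyl or a phenyl on the same carbon would separate. Also open, going by these compounds, is whether a small methoxy or an amine there would move the number at all.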